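This account rests on a few compounds, and the source may have more. Where it says the series, first, only, none or still open, it means among the compounds named here.

Working notes on the series in an assay on isolated protein for inhibition of Nitric oxide synthase, inducible (Homo sapiens), read by scintillation counting, with a stated time of 30 min, tested at 50 uM; on this read-out higher numbers stand for more inhibition at the one concentration tested (going by the name of the read-out) and lower numbers for less inhibition.

Compound 3 `CCCCC(=O)N1N=C(c2cc(OC)ccc2N)SC1(C)C` stands highest of the three numbers measured: in this assay compound 3 gives 101%. Its nearest neighbour is compound 1 `COc1ccc(N)c(C2=NN(C(C)=O)C(C)(C)S2)c1`, which in this assay gives 77.1%, and the furthest is compound 2 `CC1(C)SC(c2ccccc2N)=NN1C(=O)c1ccccc1`, which in this assay gives 39.8%. Compound 2 differs from the other two in more than one place, so its value is taken only as it stands.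

Going by the values given here, the one step measured in a single place is a number 23.9 percentage points higher from compound 1 to compound 3 (beyond the scatter), propyl in place of hydrogen on a saturated chain carbon bound to a carbonyl carbon, a lengthening of the chain on the carbonyl carbon.

Compound 4 `COc1ccc(N)c(C2=NN(C(=O)C3CCC3)C(C)(C)S2)c1` is the next member. cyclobutyl in place of butyl on a carbonyl carbon

Among the compounds with values here, no measured step covers the exchange of a butyl for a cyclobutyl group of the same size on this carbonyl carbon. Within the data shown here, the only step at this position, from compound 1 to compound 3, shows that adding carbon on the carbonyl side raised the number, and compound 4 keeps that carbon count. The expected step of a number 11 percentage points lower from compound 3 to compound 4 (beyond the scatter) is therefore none beyond the scatter, with some allowance for compound 3 already reading high in this assay. For compound 4 the estimate in this assay is 90%, ranging from 65% to 105%.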

Compound 4, a percentage reported as inhibition, at one concentration (the size of the read-out at that concentration, not a potency): 57.8%
The estimate for compound 4 lay 32.2 percentage points above the measured number, and the stated range ends above it.
By their numbers in this assay, from the lowest: compound 2; then compound 4; then compound 1; then compound 3.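

In this assay, this carbonyl position turns out to respond to more than the carbon count: butyl and cyclobutyl each hold 4 carbon atoms, yet the exchange gives a number 43.2 percentage points lower from compound 3 to compound 4 (beyond the scatter) and is a large step. Cyclobutyl also falls short of the methyl of compound 1, with a number 19.3 percentage points lower from compound 1 to compound 4 (beyond the scatter) as the step, so the gain seen with the butyl group does not extend to every larger group here, and the group on this carbonyl carbon can move the number either way from methyl. No measurement on hand accounts for the drop on going to cyclobutyl.

The compounds shown leave open whether a cyclopropyl or cyclopentyl ring on this carbonyl carbon would read like cyclobutyl, and whether a branched chain such as tert-butyl or a longer chain such as hexyl would stay with butyl or fall away from it. As far as these compounds go, since each number is a read-out at one concentration, how these compounds rank in potency also stays open, most of all for compound 3, whose number already sits at the top of the scale.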